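Swapping the Aminophenyl Ketone Arm for a Dichlorophenyl

The source may hold more compounds than are shown below. What is called first, only, known or untested is meant among the compounds shown, and "the series" means these compounds.

Two pyrazole chalcone analogues have been measured in a functional assay on NCI-H322M cells (Homo sapiens) for cytotoxicity, read by sulforhodamine B assay, with a stated time of 48 h, tested at 0.1 uM; on this read-out lower numbers stand for a stronger effect and higher numbers for a weaker effect at the one concentration tested. Compound 1 `COc1ccc(-c2cc(/C=C/C(=O)c3ccc(N)cc3)[nH]n2)cc1` gives 89%. Compound 2 `COc1cc(-c2cc(/C=C/C(=O)c3ccc(N)cc3)[nH]n2)cc(OC)c1OC` gives 103%, the higher of the two numbers, standing above compound 1 by a gap beyond the usual scatter; on this read-out compound 2 therefore shows the weaker effect of the pair.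

Compound 3 `COc1cc(-c2cc(/C=C/C(=O)c3ccc(Cl)c(Cl)c3)[nH]n2)cc(OC)c1OC` has not yet been measured in this assay. Compared with compound 2 it differs in one place: 3,4-dichlorophenyl in place of 4-aminophenyl on a carbonyl carbon.

Among the measured compounds shown here, no measured pair in this set reports what such a change does on this assay, so no step is known. The account expects compound 3 to remain close to compound 2 in this assay, with a step of a number 7 percentage points lower from compound 2 to compound 3 (within the scatter) that need not exceed the scatter. Compound 3 is estimated at 96%, within a range from 72% to 115%.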

Compound 3, a percentage reported as activity, at one concentration (the size of the read-out at that concentration, not a potency): 92%
The estimate for compound 3 lay 4 percentage points above the measured number; the range from low to high includes it.
By their numbers in this assay, from the lowest: compounds 1 and 3 (each within the scatter of the next); then compound 2.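

In this assay, among the compounds shown here, the step at the carbonyl carbon is the first one read at this position: 3,4-dichlorophenyl in place of 4-aminophenyl gives a number 11 percentage points lower from compound 2 to compound 3 (beyond the scatter), a modest change. The 4-aminophenyl group, with its hydrogen-bond donor and acceptor, is therefore not needed for the read-out at this one concentration, and a group with neither count gives a number beyond the scatter of that of compound 2. Nothing in the data accounts for this step.

The compounds shown leave open whether the step follows from the arrival of the two chlorine atoms or from the departure of the amine, a question that a plain phenyl or a 4-chlorophenyl on the same carbonyl carbon would address. From the compounds shown here alone, it also remains open whether the same exchange would give a similar step on the core of compound 1.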